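A few compounds are considered here, and "the series" means these few. Any claim that something is new, unique, unknown or untested is made for them only; others in the source may bear on it.

Measured so far in a functional assay on a cell-free system (Platelet, plasma, Homo sapiens) for inhibition; on this read-out higher numbers stand for weaker inhibition and lower numbers for stronger inhibition:
Compound 1 `Cc1ccc(N(CCN2CCC(OCC(=O)O)CC2)C(=O)c2ccc(F)cc2)cc1` gives 970 nM.
Compound 2 `O=C(O)COC1CCN(CCN(C(=O)c2ccc(F)cc2)c2ccc(Cl)cc2)CC1` gives 2000 nM.

Compound 2 thus has the higher of the two numbers, since a 2.1-fold higher number from compound 1 to compound 2 (0.31 log units; beyond the scatter). Compound 3 `O=C(O)COC1CCN(CCN(C(=O)c2cccc(Cl)c2)c2ccc(Cl)cc2)CC1` differs from compound 2 by 3-chlorophenyl in place of 4-fluorophenyl on a carbonyl carbon. Among the measured compounds shown here, no measured step touches this ring; the only step at hand, a 2.1-fold higher number from compound 1 to compound 2 (0.31 log units; beyond the scatter), alters a different part of the shared core and was modest. With no direct guide, the change from (4-fluorophenyl)carbonyl to (3-chlorophenyl)carbonyl is expected to give a small step, a 1.3-fold higher number from compound 2 to compound 3 (0.10 log units; within the scatter), weakening inhibition slightly if at all. Compound 3 is estimated at 2500 nM, within 1000 nM to 6500 nM.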

Compound 3, half-maximal inhibitory concentration: 350 nM
For compound 3 the middle estimate is 7.1-fold (0.85 log units) above the measured one; measured number outside the range, below it.
By their numbers in this assay, from the lowest: compound 3; then compound 1; then compound 2.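

In this assay the aromatic group on the carbonyl carbon proves to matter: 3-chlorophenyl in place of 4-fluorophenyl gives a 5.7-fold lower number from compound 2 to compound 3 (0.76 log units; beyond the scatter) and so stronger inhibition. Among the compounds shown here, the earlier compounds kept this group fixed, so only this pair shows that inhibition responds to a change here. No evidence is available to explain the gain.

This single change swaps fluorine for chlorine and also alters the place of the halogen on the ring, and the compounds shown cannot separate the two. A 3-fluorophenyl group on this carbonyl carbon would be needed to tell them apart.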